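Ester to acid on an aminothiophene series

The source may report more compounds than this note shows. Statements on the series, on what has been measured and on what is new or still open speak of the compounds shown alone.

Three measured compounds share one core. Compound 1 `COC(=O)c1c(Nc2ccc(C)cc2)sc(C(=O)c2ccc(OC)cc2)c1C` and compound 3 `COC(=O)c1c(Nc2ccc(Cl)cc2)sc(C(=O)c2ccc(OC)cc2)c1C` differ only in the group on the aniline ring. In a functional assay, with a stated time of 150 min, tested at 10 ug/mL (on this read-out higher numbers stand for a stronger effect at the one concentration tested and lower numbers for a weaker effect), compound 1 gives "not active" (no number reported). In this assay compound 3 gives "not active" (no number reported). For the measured compounds named here, compound 2 `COC(=O)c1c(Nc2ccc(OC)cc2)sc(C(=O)c2ccc(OC)cc2)c1C` gives 5.9% in this assay and stands as the only entry with a number; the other two return no figure. Compound 4 `COc1ccc(Nc2sc(C(=O)c3ccc(OC)cc3)c(C)c2C(=O)O)cc1` is not yet measured. It differs from compound 2 by hydrogen in place of methyl on an oxygen next to a carbonyl group. Going by the values given here, no step between measured compounds is recorded, so nothing shows how this change acts. With compound 2 at 5.9%, the step of a number 0.9 percentage points lower from compound 2 to compound 4 (within the scatter) is expected to stay within the scatter, in no particular direction. Compound 4 is estimated at 5%, range 0% to 15%.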

Compound 4, a percentage reported as activity, at one concentration (the size of the read-out at that concentration, not a potency): 23.5%
Compound 4: the middle estimate sits 18.5 percentage points below what was measured; measured number outside the range, above it.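

Methoxycarbonyl to carboxy gives the first readable step in the series: this assay records a number 17.6 percentage points higher from compound 2 to compound 4 (beyond the scatter). For the compounds shown here, the read-out at this position therefore responds to hydrogen in place of methyl on the oxygen, which the earlier compounds, differing only on the aniline ring, could not show. No measurement at hand accounts for the step.

Open, as far as these compounds go, is whether an amide or an ethyl ester at this position would track the carboxy or the methoxycarbonyl compound. Also open, from the compounds shown here alone, is whether the same change would give a number on the cores of compound 1 and compound 3.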